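Aminothiophene ketones: aryl substitution on the thiophene ring

A few compounds are considered here, and "the series" means these few. Any claim that something is new, unique, unknown or untested is made for them only; others in the source may bear on it.

Of the compounds shown here, two have been measured in an assay on CHO cells for displacement of a labelled ligand from adenosine receptor A3 (Homo sapiens), read by scintillation counting, tested at 10 uM; on this read-out lower numbers stand for less inhibition and higher numbers for more inhibition at the one concentration tested (going by the name of the read-out). Compound 1 `CC(C)Cc1csc(N)c1C(=O)c1ccc(Cl)cc1` gives 1% in this assay. Compound 2 `CC(C)(C)Cc1csc(N)c1C(=O)c1ccc(Cl)cc1` gives 5% in this assay, a value within the scatter of that of compound 1; the step of a number 4 percentage points higher from compound 1 to compound 2 (within the scatter) therefore shows no effect beyond the scatter, and compound 2 cannot be set apart from compound 1 on these numbers. Both values sit near the bottom of the scale.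

Compound 3 `CC(C)(C)Cc1c(-c2ccc(F)cc2)sc(N)c1C(=O)c1ccc(Cl)cc1` differs from compound 2 by one change: 4-fluorophenyl in place of hydrogen on an aromatic carbon. Among the compounds with values here, no measured step concerns this kind of change; the only step on record, that from compound 1 to compound 2, alters a saturated chain and says nothing about an aryl group entering at an aromatic carbon of the five-membered ring. The size and direction of the step in this assay are thus open, and the estimate can rest only on the low level of the two measured values.

Compound 3 is expected to give about 15% in this assay, within a range from 0% to 45%. Within the data shown here, the step of a number 10 percentage points higher from compound 2 to compound 3 (within the scatter) is the estimated change, with no measured precedent behind it.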

Compound 3, a percentage reported as inhibition, at one concentration (the size of the read-out at that concentration, not a potency): 9%
Compound 3: the middle estimate sits 6 percentage points above what was measured; low and high end bracket the measured number.
By their numbers in this assay, from the lowest: compounds 1, 2 and 3 (each within the scatter of the next).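

Within the data shown here, the aromatic carbon next to the ring sulfur and next to the ring atom that bears a neopentyl group now has a first reading in this assay: the exchange of hydrogen for 4-fluorophenyl gives a number 4 percentage points higher from compound 2 to compound 3 (within the scatter). A whole aromatic ring can therefore enter at this position without any effect beyond the scatter, and compound 3, like compound 2, stays near the bottom of the scale at the one concentration tested. No supporting measurement is available to explain this result.

Going by these compounds, whether this reading is particular to 4-fluorophenyl remains open, as a plain phenyl, a pyridine ring, a methyl group or a basic amine on a short chain at the same aromatic carbon might read differently. On these data alone, since compound 2 already sits so low that a loss at this position could hardly show, it also remains open whether 4-fluorophenyl would read the same on a compound with a high value, for instance one carrying a different group in place of neopentyl or of the (4-chlorophenyl)carbonyl group.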